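Replacing a urea with a bicyclic amide on the azetidine core

The source may hold more compounds than are shown below. What is called first, only, known or untested is meant among the compounds shown, and "the series" means these compounds.

The series rests on a shared core, an azetidine bearing an oxadiazole that carries a halogenated phenyl ring, with an acyl group on the ring nitrogen. Compound 1 `O=C(c1ccccc1F)N1CC[C@H]1c1nc(-c2cccc(F)c2)no1` carries a fluorobenzoyl group; in an assay on HEK293 cells for positive allosteric modulation of metabotropic glutamate receptor 5 (Homo sapiens), read by FLIPR (on this read-out lower numbers stand for an effect already at smaller amounts and higher numbers for an effect only at larger amounts of compound), compound 1 reaches only > 10000 nM, a limit of the assay and not a number. Compound 2 `CC1CCN(C(=O)N2CC(c3nc(-c4cccc(Cl)c4)no3)C2)C1` carries a urea formed with 3-methylpyrrolidin-1-yl; in this assay compound 2 likewise stops at > 10000 nM, again a limit rather than a number. Going by the values given here, compound 3 `O=C(c1ccc(F)cc1)N1CC(c2nc(-c3cccc(F)c3)no2)C1`, with a differently placed fluorine on its benzoyl group, gives 2400 nM, the one numerical value shown. Compound 2 thus stands at the limit of > 10000 nM in this assay, at which 2 of the 3 values shown sit.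

Compound 4 `O=C([C@@H]1CC2CCC1C2)N1CC(c2nc(-c3cccc(Cl)c3)no2)C1` differs from compound 2 by a group of 7 heavy atoms (7 carbon; 2 five-membered non-aromatic rings of carbon only) in place of a group of 6 heavy atoms (5 carbon, 1 nitrogen; one five-membered non-aromatic ring with 1 hetero atom), on a carbonyl carbon, and its chloro-substituted oxadiazole aryl ring is kept. No measured pair differs in exactly this way, so the step has no precedent among the compounds shown. Compound 3 shows that a benzoyl group on the same core can give a number rather than a limit, and the step expected is an at least 3.3-fold lower number from compound 2 to compound 4 (0.52 log units; beyond the scatter), a move toward an effect at smaller amounts. Compound 4 is estimated at 3000 nM, with a range from 800 nM to 10000 nM.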

Compound 4, half-maximal effective concentration: 98 nM
Compound 4: middle estimate off by 31-fold (1.49 log units), on the high side; measured number below the stated range.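

On a carbonyl carbon whose other neighbours are an amide-type nitrogen in a ring, replacing 3-methylpyrrolidin-1-yl with a group of 2 five-membered non-aromatic rings of carbon only gives an at least 100-fold lower number from compound 2 to compound 4 (2.00 log units; beyond the scatter) in this assay. This shows that the group on this carbonyl carbon can by itself carry a large change with the chloro-substituted aryl ring kept, even though neither group has hydrogen-bond donors, hydrogen-bond acceptors or a net charge, so these counts do not distinguish them. The size of the step is open-ended, as its starting point is a limit and not a number for compound 2: the limit of > 10000 nM in this assay, at which 2 of the 4 values shown sit.

With a single step, the compounds shown cannot separate the loss of the ring nitrogen attached to the carbonyl from the gain of the second carbon ring, and a plain cyclopentyl group on the same carbonyl carbon would bear on that question. They also leave open how much depends on the defined stereocentre of the entering group, and whether the same group would give a similar result with a fluorine in place of the chlorine on the aryl ring.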